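This account rests on a few compounds, and the source may have more. Where it says the series, first, only, none or still open, it means among the compounds named here.

Compound 1 `CN(C)c1ccc(C(=O)N(CCC(=O)NCc2ccc(Cl)cc2)Cc2ccc(C(=O)NO)cc2)cc1` gives 610 nM in a functional assay on CHP-134 cells (Homo sapiens) for antiproliferative activity, with a stated time of 72 h; a lower number here means a stronger inhibitor, a higher number a weaker inhibitor.
Compound 2 `COc1ccc(C(=O)N(CCC(=O)NCc2ccccc2)Cc2ccc(C(=O)NO)cc2)cc1` gives 1900 nM.
Compound 3 `Cc1ccc(NC(=O)CCN(Cc2ccc(C(=O)NO)cc2)C(=O)c2ccc(N(C)C)cc2)cc1` gives 540 nM.

Among these three, compound 2 has the highest number, so it is the weakest inhibitor measured here; both compound 1 and compound 3 lie beyond the scatter below it. Compound 4 `Cc1ccc(C(=O)N(CCC(=O)NCc2ccccc2)Cc2ccc(C(=O)NO)cc2)cc1` differs from compound 2 by methyl in place of methoxy on an aromatic carbon. Within the data shown here, the only measured step, a 1.1-fold lower number from compound 1 to compound 3 (0.05 log units; within the scatter), changes the amide tail on the other side of the shared core, not the group on the aromatic carbon, so it does not bear on this change. Among the measured compounds shown here, no measured pair shows what methyl in place of methoxy does here. The expectation for compound 4 is therefore a step of a 1.1-fold lower number from compound 2 to compound 4 (0.05 log units; within the scatter), that is, no change beyond the scatter. Compound 4 is estimated at 1700 nM, within 600 nM to 5000 nM.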

Compound 4, half-maximal inhibitory concentration: 1100 nM
Compound 4: the middle estimate sits 1.5-fold (0.19 log units) above what was measured; the measured number falls inside the stated range.
By their numbers in this assay, from the lowest: compounds 3, 1, 4 and 2 (each within the scatter of the next, the first and the last beyond it).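

Placing methyl in place of methoxy on this aromatic carbon, para to a large group, gives a 1.7-fold lower number from compound 2 to compound 4 (0.24 log units; within the scatter) in this assay. This pair therefore shows that, with this amide tail, the exchange removes an oxygen and the hydrogen-bond acceptor counted on methoxy without moving the number beyond the scatter. Nothing available here offers an explanation for this result.

On these data alone, what a carboxylic acid or a propyl chain at this place would do remains open. So does whether the same exchange gives a similar step with other amide tails on the shared core.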